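Swapping 6-aminopyridin-3-yl for 5-aminopyridin-3-yl in compound 2

A few compounds are considered here, and "the series" means these few. Any claim that something is new, unique, unknown or untested is made for them only; others in the source may bear on it.

In a physicochemical assay for solubility, read by LC-MS, in phosphate buffer, with a stated time of 24 h, at pH 6.8 (a higher number here means a more soluble compound, a lower number a less soluble compound), compound 1 (`C[C@H](NC(=O)c1cccc(F)c1)c1ccc(NC(=O)N2CC(c3ccc(N)nc3)C2)cc1`) gives 32000 nM while compound 2 (`C[C@H](NC(=O)c1ncccn1)c1ccc(NC(=O)N2CC(c3ccc(N)nc3)C2)cc1`) gives 300000 nM and compound 3 (`CCC(=O)N[C@@H](C)c1ccc(NC(=O)N2CC(c3ccc(N)nc3)C2)cc1`) gives 760000 nM on the same scale, leaving compound 2 second highest of the three. Compound 4 (`C[C@H](NC(=O)c1ncccn1)c1ccc(NC(=O)N2CC(c3cncc(N)c3)C2)cc1`) alters one group of compound 2 (5-aminopyridin-3-yl in place of 6-aminopyridin-3-yl on a saturated ring carbon), with 5-aminopyridin-3-yl in place of 6-aminopyridin-3-yl on a saturated ring carbon. Among the measured compounds shown here, no measured step touches that group. All three change the group on a carbonyl carbon instead: one modest (a 9.4-fold higher number from compound 1 to compound 2 (0.97 log units; beyond the scatter)), one large (a 24-fold higher number from compound 1 to compound 3 (1.38 log units; beyond the scatter)) and one modest (a 2.5-fold higher number from compound 2 to compound 3 (0.40 log units; beyond the scatter)). They show the spread of the series but give no direction for this swap. The expectation therefore starts from compound 2 at 300000 nM and stays close to it. The estimated change is small (a 1.2-fold lower number from compound 2 to compound 4 (0.08 log units; within the scatter)), probably none beyond the scatter. Compound 4 is estimated at 250000 nM (range 80000 nM to 700000 nM).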

Compound 4, solubility: 300000 nM
Estimate against measurement, compound 4: 1.2-fold (0.08 log units) below; the measured number falls inside the stated range.
By their numbers in this assay, from the lowest: compound 1; then compounds 2 and 4 (each within the scatter of the next); then compound 3.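

Among the compounds shown here, the first step at this position, 5-aminopyridin-3-yl in place of 6-aminopyridin-3-yl on a saturated ring carbon, gives no change at the digits printed from compound 2 to compound 4 (within the scatter) in this assay. With pyrimidin-2-yl on the carbonyl carbon, this change of aminopyridine isomer therefore leaves the reading within the scatter. Nothing available gives a measured reason for this outcome.

As far as these compounds go, whether the swap reads the same with 3-fluorophenyl or ethyl on the carbonyl carbon remains open. So does what a plain phenyl or a 5-hydroxypyridin-3-yl would give on the saturated ring carbon.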